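Turning one stereocentre in the chroman amide series

This account rests on a few compounds, and the source may have more. Where it says the series, first, only, none or still open, it means among the compounds named here.

Among the compounds with values here, compound 3, drawn as `COc1ccc2c(c1)C[C@@H](C(=O)Nc1ccc(-c3cn[nH]c3)cc1OCCCO)CO2`, is the only member of this set with a number attached: in an assay on A7R5 cells for inhibition of Rho-associated protein kinase 2 (Rattus norvegicus), with a stated time of 1 h (on this read-out higher numbers stand for weaker inhibition and lower numbers for stronger inhibition), compound 3 gives 519 nM. Compound 1, drawn as `COc1ccc2c(c1)C[C@H](C(=O)Nc1ccc(-c3cn[nH]c3)cc1O[C@@H]1CCN(C)C1)CO2`, reaches only a limit in this assay, giving < 4 nM. Compound 2, drawn as `COc1ccc2c(c1)C[C@H](C(=O)Nc1ccc(-c3cn[nH]c3)cc1O[C@H]1CCN(C)C1)CO2`, likewise sits at a limit, giving < 4 nM. The step that the two limits leave unreadable from compound 1 to compound 2 cannot be sized, because the limit of < 4 nM in this assay, at which 2 of the 3 values shown sit, hides both ends; what is known is only (the fact that compounds 1 and 2 differ only in the configuration as drawn).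

Compound 4, drawn as `COc1ccc2c(c1)C[C@H](C(=O)Nc1ccc(-c3cn[nH]c3)cc1OCCCO)CO2`, is the partner of compound 3 that has not been measured. The change is the two compounds have the same atoms and bonds and differ only in configuration as drawn: 1 of 1 stereo elements differ; a stereocentre at a saturated ring carbon is drawn R in compound 3 and S in compound 4. Within the data shown here, no measured step in this set inverts the same stereocentre, so the size of the effect has no direct precedent here; the only inversion on record is the unreadable one between compound 1 and compound 2, which concerns a different stereocentre. The estimate for compound 4 is therefore loosely held: the step of a 5.2-fold lower number from compound 3 to compound 4 (0.72 log units; beyond the scatter) is expected, and compound 4 is expected to give 100 nM, within a range from 15 nM to 600 nM.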

Compound 4, half-maximal inhibitory concentration: < 4 nM
Compound 4 ended at the assay's limit; the forecaster's own chance of this, stated with the estimate: 10%; middle value at least 25-fold (1.39 log units) from the limit.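

Inverting the stereocentre at the saturated ring carbon alone brings an at least 120-fold lower number from compound 3 to compound 4 (2.11 log units; beyond the scatter) in this assay, the first readable size for a change of configuration in this set, where the earlier inversion could not be sized. The step can be laid on this one centre, with the S form as drawn giving the lower number, because nothing else separates the pair: the fact that compounds 3 and 4 differ only in the configuration as drawn In this assay compound 4 gives < 4 nM, which is a limit and not a number, so the full size of the step stays hidden.

From the compounds shown here alone, the steps among compounds 1, 2 and 4, including 3-hydroxypropyl in place of 1-methylpyrrolidin-3-yl, cannot be read because all three ends sit at one limit: the limit of < 4 nM in this assay, at which 3 of the 4 values shown sit. It remains open how far the same inversion reaches with other groups on that oxygen, such as 3-aminopropyl or a carboxylic acid chain.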